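The source may hold more compounds than are shown below. What is called first, only, known or untested is meant among the compounds shown, and "the series" means these compounds.

Working notes on the series, around the step from compound 3 to compound 4.

Among the compounds with values here, compound 3 `CNC(=O)c1cccc(S(=O)(=O)Oc2ccc(-c3cncn3C3CCN(C(=O)c4ccc(S(C)(=O)=O)cc4)CC3)cc2)c1` gives 202 nM in an assay on HEK293 cells for antagonist activity at P2X purinoceptor 7 (Homo sapiens), read by fluorescence, with a stated time of 2 h; on this read-out lower numbers stand for stronger inhibition and higher numbers for weaker inhibition; that is the highest of the three numbers measured so far, and it sits nearest to compound 2 `CS(=O)(=O)c1ccc(C(=O)N2CCC(n3cncc3-c3ccc(OS(=O)(=O)c4cccc(C#N)c4)cc3)CC2)cc1`, which gives 143 nM, and furthest from compound 1 `O=C(NC1CC1)c1cccc(S(=O)(=O)Oc2ccc(-c3cncn3C3CCN(C(=O)c4ccc(Cl)c(C(F)(F)F)c4)CC3)cc2)c1`, which gives 88 nM. Within the data shown here, the only single-point step measured, a 1.4-fold higher number from compound 2 to compound 3 (0.15 log units; within the scatter), covers methylcarbamoyl in place of cyano on an aromatic carbon and stays within the scatter. Among the measured compounds shown here, compound 1 and compound 3 differ in two places, so their two values show only that the cyclopropylcarbamoyl compound with its own benzoyl group gives the lower number.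

Compound 4 `CS(=O)(=O)c1ccc(C(=O)N2CCC(n3cncc3-c3ccc(OS(=O)(=O)c4cccc(C(=O)NC5CC5)c4)cc3)CC2)cc1` has not been measured. It differs from compound 3 by cyclopropyl in place of methyl on an amide-type nitrogen. For the measured compounds named here, no measured step covers this change alone; the one step measured on the same aromatic carbon was small, and compound 1 with its cyclopropylcarbamoyl group gave 88 nM, which argues against a large loss. The step is therefore expected to be a 1.3-fold lower number from compound 3 to compound 4 (0.13 log units; within the scatter), small and not clearly beyond the scatter. Compound 4 is estimated at 150 nM, with a range from 70 nM to 330 nM.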

Compound 4, half-maximal inhibitory concentration: 400 nM
Compound 4: the middle estimate sits 2.7-fold (0.43 log units) below what was measured; measured number outside the range, above it.
By their numbers in this assay, from the lowest: compounds 1, 2, 3 and 4 (each within the scatter of the next, the first and the last beyond it).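

In this assay, within the data shown here, the first step on the amide nitrogen itself, a 2.0-fold higher number from compound 3 to compound 4 (0.30 log units; within the scatter), stays within the scatter, so cyclopropyl in place of methyl at this place cannot be told apart from no change on this pair alone. Measured against the cyano compound, however, the cyclopropylcarbamoyl group gives a step beyond the scatter, a 2.8-fold higher number from compound 2 to compound 4 (0.45 log units; beyond the scatter), whereas the methylcarbamoyl group on the same aromatic carbon gives a 1.4-fold higher number from compound 2 to compound 3 (0.15 log units; within the scatter) and does not leave the scatter. With cyclopropylcarbamoyl held fixed, the exchange on the carbonyl carbon can now be read in one place, and a 4.5-fold higher number from compound 1 to compound 4 (0.66 log units; beyond the scatter) shows that 4-chloro-3-(trifluoromethyl)phenyl goes with the lower number and 4-(methylsulfonyl)phenyl with the higher one.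

From the compounds shown here alone, it remains open whether an ethyl or longer alkyl chain on the amide nitrogen, an unsubstituted carbamoyl group or a carboxylic acid on that aromatic carbon would extend the small differences seen here, and whether the exchange on the carbonyl carbon gives a step of like size with cyano or methylcarbamoyl in place of cyclopropylcarbamoyl. Nothing available bears on what lies behind these steps.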